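The source may report more compounds than this note shows. Statements on the series, on what has been measured and on what is new or still open speak of the compounds shown alone.

In a functional assay on NCI/ADR-RES cells (Homo sapiens) for inhibition, read by spectrophotometry and sulforhodamine B assay, with a stated time of 48 h (a lower number here means a stronger inhibitor of growth, a higher number a weaker inhibitor of growth), three compounds have been measured so far. Compound 1 (`Cc1ccc(N2C(=O)CS/C2=N/N=C/c2c[nH]c3ccc(Br)cc23)cc1`) gives 64600 nM, compound 2 (`S=C(N/N=C/c1c[nH]c2ccc(Br)cc12)Nc1cccc2ccccc12`) gives 6180 nM, and compound 3 (`Cc1ccc(NC(=S)N/N=C/c2c[nH]c3ccccc23)cc1`) gives 1460 nM. Compound 2 therefore holds the middle place of the three, with compound 3 lower and compound 1 higher, and both gaps lie beyond the scatter.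

Compound 4 (`S=C(N/N=C/c1c[nH]c2ccccc12)Nc1cccc2ccccc12`) has not yet been measured. It arises from compound 2 through a single change, hydrogen in place of bromo on an aromatic carbon. For the measured compounds named here, no measured pair differs by this change alone, so the data offer only indirect guidance. The expectation of a modest move toward a lower number rests on compound 3, which carries no bromo and gives 1460 nM, although it also differs from compound 2 in a second place. The expected change is a 2.1-fold lower number from compound 2 to compound 4 (0.31 log units; beyond the scatter). The estimated value for compound 4 is 3000 nM, with an expected range of 1000 nM to 9000 nM.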

Compound 4, concentration for 50% growth inhibition: 6480 nM
Compound 4: the middle estimate sits 2.2-fold (0.33 log units) below what was measured; the measured number falls inside the stated range.
By their numbers in this assay, from the lowest: compound 3; then compounds 2 and 4 (each within the scatter of the next); then compound 1.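

In this assay, the exchange of bromo for hydrogen on this aromatic carbon gives a 1.0-fold higher number from compound 2 to compound 4 (0.02 log units; within the scatter), so bromo at this position makes no readable difference to the number when the rest of the structure is held fixed. Compound 3, which also lacks bromo, gives 1460 nM while compound 4 gives 6480 nM, so the lack of bromo alone does not account for the low number of compound 3. Nothing shown here offers a reason why the number stays put at this position.

As far as these compounds go, it remains open whether bromo would be equally without effect in a bromo counterpart of compound 3. Also open, from the compounds shown here alone, is whether a methoxy group or an amine on this same carbon would shift the number.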